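The source may hold more compounds than are shown below. What is called first, only, known or untested is meant among the compounds shown, and "the series" means these compounds.

Compound 1 `Cc1cc2[nH]nc(N)c2c(=O)[nH]1` in an assay on isolated protein for inhibition of serine/threonine-protein kinase Chk2 (Homo sapiens), read by mobility shift assay, tested at 30 uM (on this read-out higher numbers stand for more inhibition at the one concentration tested (going by the name of the read-out) and lower numbers for less inhibition), gives 27%.
Compound 2 `CC(C)(C)c1cc2[nH]nc(N)c2c(=O)[nH]1` in this assay gives 21%.
Compound 3 `Cc1cc2nn(-c3ccccc3)c(N)c2c(=O)[nH]1` in this assay gives -4%.

Compound 1 and compound 2 differ by one change, (tert-butyl in place of methyl on an aromatic carbon), and in this assay this made a number 6 percentage points lower from compound 1 to compound 2 (within the scatter). Compound 3 stands lowest of the three measured numbers, beyond the scatter from both compound 2 and compound 1; the difference between its core and the core of compound 1 is not broken down here. Compound 4 `CC(C)(C)c1cc2nn(-c3ccccc3)c(N)c2c(=O)[nH]1` is related to compound 3 by tert-butyl in place of methyl on an aromatic carbon, the same change as from compound 1 to compound 2, made at the same place. Because the earlier step was a number 6 percentage points lower from compound 1 to compound 2 (within the scatter), a step of about a number 2 percentage points lower from compound 3 to compound 4 (within the scatter) is expected here, and compound 4 is estimated at -6%, with a likely range from -22% to 10%.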

Compound 4, a percentage reported as inhibition, at one concentration (the size of the read-out at that concentration, not a potency): 5%
For compound 4 the middle estimate is 11 percentage points below the measured one, within the range that was stated.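

In this assay, tert-butyl in place of methyl on an aromatic carbon gave a number 9 percentage points higher from compound 3 to compound 4 (within the scatter). Set beside the earlier step, the change does not carry over as one fixed step from one core to the other: the same change on two cores in this assay, a number 6 percentage points lower (within the scatter) from compound 1 to compound 2 and a number 9 percentage points higher (within the scatter) from compound 3 to compound 4, 15 percentage points apart, beyond the scatter of two such steps. Within the data shown here, this does not show that the change truly acts in opposite directions on the two cores, as each step taken alone lies within the scatter and only two pairs are at hand.

The compounds shown leave open how a longer chain, an amine or a carboxylic acid would read in place of methyl or tert-butyl on this aromatic carbon. Also open, on these data alone, is whether the same comparison would hold on a core carrying benzyl in place of phenyl.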